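Swapping Decyl for Cyclopropyl

This account rests on a few compounds, and the source may have more. Where it says the series, first, only, none or still open, it means among the compounds named here.

In an ADME assay on HFF cells (Homo sapiens) for cytotoxicity, read by MTT assay, with a stated time of 72 h (a higher number here means a weaker inhibitor, a lower number a stronger inhibitor), compound 1 (`O=C1O[C@H]([C@@H](O)Cn2cc(-c3ccc(Br)cc3)nn2)C(OCc2ccccc2)=C1OCc1ccccc1`) gives 5100 nM. Compound 2 (`CCCCCCCCCCc1cn(C[C@H](O)[C@H]2OC(=O)C(OCc3ccccc3)=C2OCc2ccccc2)nn1`) reads > 100000 nM, which is a limit and not a number; this is the limit of > 100000 nM in this assay, at which 1 of the 2 values shown sits. Compound 3 (`O=C1O[C@H]([C@@H](O)Cn2cc(C3CC3)nn2)C(OCc2ccccc2)=C1OCc1ccccc1`) has cyclopropyl in place of decyl on an aromatic carbon. Among the compounds with values here, one measured step bears on this change: an at least 19-fold higher number from compound 1 to compound 2 (1.29 log units; beyond the scatter), which is large and beyond the scatter, and which brought in decyl in place of 4-bromophenyl. Losing decyl may undo part of that step, though cyclopropyl is not 4-bromophenyl. The expected change is an at least 4.0-fold lower number from compound 2 to compound 3 (0.60 log units; beyond the scatter), towards a lower number. Compound 3 is expected at 25000 nM, with an estimated range of 7000 nM to 90000 nM.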

Compound 3, half-maximal inhibitory concentration: 24300 nM
Beside the measured number, compound 3's estimate is 1.0-fold (0.01 log units) above it; low and high end bracket the measured number.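

In this assay, cyclopropyl on this aromatic carbon gives an at least 4.1-fold lower number from compound 2 to compound 3 (0.61 log units; beyond the scatter), so a much smaller group recovers part of what was lost with decyl. It does not recover all of it, as replacing 4-bromophenyl with cyclopropyl gives a 4.8-fold higher number from compound 1 to compound 3 (0.68 log units; beyond the scatter), which places compound 3 between the other two. Compound 2 is a limit and not a number, so the first step gives only a minimum: the limit of > 100000 nM in this assay, at which 1 of the 3 values shown sits.

On these data alone, whether a plain phenyl or a shorter chain such as butyl would read closer to compound 1 remains open. So does the effect of an amine at this position.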